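The source may hold more compounds than are shown below. What is called first, only, known or untested is meant among the compounds shown, and "the series" means these compounds.

Compound 1 `COCCNS(=O)(=O)c1ccc(C)c(C#Cc2cc(Cl)ccc2OCC(=O)O)c1`: 3.6 nM
Compound 2 `CC(C)c1ccc(S(C)(=O)=O)cc1C#Cc1cc(Cl)ccc1OCC(=O)O`: 4.6 nM

In an assay on CHO cells for displacement of a labelled ligand from prostaglandin D2 receptor 2 (Homo sapiens), read by scintillation counting (a lower number here means a stronger inhibitor, a higher number a weaker inhibitor), compound 2 holds the higher of the two numbers shown, yet its gap to compound 1 lies within the scatter, so the two are not told apart. Compound 3 `Cc1ccc(S(C)(=O)=O)cc1C#Cc1cc(Cl)ccc1OCC(=O)O` differs from compound 2 by methyl in place of isopropyl on an aromatic carbon. Among the compounds with values here, no measured pair shows this change, so its effect is unknown; an expectation of a small step, if any, towards a weaker inhibitor follows only from compound 1, which carries a methyl at this place and gives 3.6 nM. Compound 3 is therefore estimated at 6 nM, between 2 nM and 18 nM. The expected step of a 1.3-fold higher number from compound 2 to compound 3 (0.12 log units; within the scatter) stays within the scatter.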

Compound 3, inhibition constant: 5 nM
Beside the measured number, compound 3's estimate is 1.2-fold (0.08 log units) above it; measured number inside the range.
By their numbers in this assay, from the lowest: compounds 1, 2 and 3 (each within the scatter of the next).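

In this assay, methyl in place of isopropyl on this aromatic carbon now has a measured pair, and it gives a 1.1-fold higher number from compound 2 to compound 3 (0.04 log units; within the scatter), so the two groups are not told apart at this place. On the sulfonyl sulfur, methyl in place of (2-methoxyethyl)amino gives a 1.4-fold higher number from compound 1 to compound 3 (0.14 log units; within the scatter), so that change cannot be read as a difference either. Nothing available explains these results.

From the compounds shown here alone, whether an amine on the aromatic carbon, or a longer chain on the sulfonyl sulfur, would give a step beyond the scatter remains open.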